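Switching the benzyl substituent: from fluorine to a tert-butyl group

The compounds below may be only part of what the source reports. "The series", "measured", "known", "first", "only" and "open" are said of these compounds alone.

Compound 3 `COC(=O)c1ccc(NCc2cncn2Cc2ccccc2F)cc1-c1ccccc1` has no number yet in a toxicity assay on NIH3T3 cells (Mus musculus) for cytotoxicity, read by resazurin assay; a higher number here means that more compound is needed for the effect, a lower number that less compound is needed; its entry stands as "not determined" (no result reported). Its relatives give some footing. Compound 1 `COC(=O)c1ccc(NCc2cncn2Cc2ccc(Cl)cc2)cc1-c1ccccc1` gives 25000 nM in this assay. Compound 2 `COC(=O)c1ccc(NCc2cncn2Cc2ccc(F)cc2F)cc1-c1ccccc1` returns only a limit in this assay, recorded as > 1000 nM, so no single number is known for it. The one measured step, a step that the limit leaves unreadable from compound 1 to compound 2, therefore cannot be sized, and the limit of > 1000 nM in this assay, at which 1 of the 3 values shown sits, marks the only shown value sitting at that limit.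

The change from compound 3 to compound 4 `COC(=O)c1ccc(NCc2cncn2Cc2cccc(C(C)(C)C)c2)cc1-c1ccccc1` is 3-(tert-butyl)phenyl in place of 2-fluorophenyl on a saturated chain carbon bound to an aromatic nitrogen. Among the measured compounds shown here, no measured step bears directly on this change, and the single step available is unreadable, so no direction or size of effect in this assay can be taken from the data. The expectation therefore rests on the observation that both measured relatives sit at high or limit-level concentrations in this assay. Compound 4 is estimated at 20000 nM, expected to fall between 5000 nM and 80000 nM, with a fair chance that only a limit is reported.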

Compound 4, half-maximal effective concentration: > 1000 nM
Compound 4 gave a limit, no number; the forecaster's own chance of this, stated with the estimate: 40%; the middle value does not contradict the limit.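

Compound 4 returns a limit rather than a number in this assay, as compound 2 does, so no step linking compound 4 to compound 1 or compound 2 can be read: the limit of > 1000 nM in this assay, at which 2 of the 4 values shown sit.

Open, from the compounds shown here alone, is whether changing the benzyl group shifts the concentration needed for cytotoxicity.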